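Dichlorophenyl for nitrophenyl on the oxazole-bearing series

This account rests on a few compounds, and the source may have more. Where it says the series, first, only, none or still open, it means among the compounds named here.

Measured compounds:
compound 1 `COC(=O)c1c(NCCCNc2ccnc3cc(Cl)ccc23)noc1-c1ccc([N+](=O)[O-])cc1` — 107000 nM
compound 2 `COC(=O)c1c(NCCCNc2ccnc3cc(Cl)ccc23)noc1-c1ccccc1[N+](=O)[O-]` — "not determined" (no result reported)

Compound 1 was tested in an ADME assay on J774.A1 cells (Mus musculus) for cytotoxicity, read by MTT assay, with a stated time of 48 h (a higher number here means that more compound is tolerated, a lower number that less compound is tolerated), and gives 107000 nM. For compound 2 the result in this assay reads "not determined" (no result reported), so compound 2 stands nowhere on the scale shown, and the only measured anchor is compound 1. Compound 3 `COC(=O)c1c(NCCCNc2ccnc3cc(Cl)ccc23)noc1-c1ccc(Cl)cc1Cl` differs from compound 2 in one place: 2,4-dichlorophenyl in place of 2-nitrophenyl on an aromatic carbon. For the measured compounds named here, with no step measured, the change is expected to move tolerance in this assay little, if at all, beyond the usual scatter, in no clear direction. Compound 3 is therefore estimated at 90000 nM, within 30000 nM to 250000 nM.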

Compound 3, half-maximal cytotoxic concentration: 31100 nM
Beside the measured number, compound 3's estimate is 2.9-fold (0.46 log units) above it, within the range that was stated.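

In this assay the phenyl group on the shared core has its first measured change: 2,4-dichlorophenyl in place of 4-nitrophenyl gives a 3.4-fold lower number from compound 1 to compound 3 (0.54 log units; beyond the scatter) and so marks this position as one where the substituents can shift tolerance beyond the scatter. Compound 2 has no number, so the step from compound 2 to compound 3 cannot be read. Nothing measured here bears on the cause of the step. From the compounds shown here alone, whether a single chlorine on this phenyl ring accounts for the change, and how an amine or a carboxylic acid there would behave in this assay, remains open.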